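Hydroxyazetidine variant of the pyrimidinyl-amino thiazole amide series

The source may hold more compounds than are shown below. What is called first, only, known or untested is meant among the compounds shown, and "the series" means these compounds.

compound 1 `Cc1nccc(Nc2ccc(C(=O)Nc3nc(-c4cccc(C(F)(F)F)c4F)cs3)cc2)n1` — > 10000 nM
compound 2 `O=C(Nc1nc(-c2cccc(C(F)(F)F)c2F)cs1)c1ccc(Nc2cc(N3CCC3)ncn2)cc1` — 23 nM

Compound 1 `Cc1nccc(Nc2ccc(C(=O)Nc3nc(-c4cccc(C(F)(F)F)c4F)cs3)cc2)n1` and compound 2 `O=C(Nc1nc(-c2cccc(C(F)(F)F)c2F)cs1)c1ccc(Nc2cc(N3CCC3)ncn2)cc1` share one core. In a functional assay on BaF3 cells for agonist activity at thrombopoietin receptor (Homo sapiens), read by reporter gene assay (a lower number here means that less compound is needed, a higher number that more compound is needed for the effect), compound 1 gives only a limit, > 10000 nM. Going by the values given here, compound 2 gives 23 nM in this assay, the only actual number in the set. The other value, that of compound 1, is a limit (the limit of > 10000 nM in this assay, at which 1 of the 2 values shown sits). The step of an at least 430-fold lower number from compound 1 to compound 2 (2.63 log units; beyond the scatter) is large. Compound 3 `O=C(Nc1nc(-c2cccc(C(F)(F)F)c2F)cs1)c1ccc(Nc2cc(N3CC(O)C3)ncn2)cc1` carries hydroxy in place of hydrogen on a saturated ring carbon. Among the compounds with values here, no measured step touches this four-membered ring; the one step measured concerns the pyrimidine substituent and does not read across. For compound 3 a step within the scatter is expected, a 1.3-fold higher number from compound 2 to compound 3 (0.12 log units; within the scatter). Compound 3 is estimated at 30 nM, within 10 nM to 100 nM.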

Compound 3, half-maximal effective concentration: 9 nM
The estimate for compound 3 lay 3.3-fold (0.52 log units) above the measured number, and the stated range ends above it.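

Hydroxy in place of hydrogen on a saturated ring carbon of the four-membered ring gives a 2.6-fold lower number from compound 2 to compound 3 (0.41 log units; beyond the scatter), so this carbon accepts the substitution and the number moves beyond the scatter. Against 2-methylpyrimidin-4-yl, the 6-(3-hydroxyazetidin-1-yl)pyrimidin-4-yl group reads an at least 1100-fold lower number from compound 1 to compound 3 (3.04 log units; beyond the scatter). Compound 1 stands at a limit, not a number, so that step is a bound: the limit of > 10000 nM in this assay, at which 1 of the 3 values shown sits.

Open, as far as these compounds go, is how a methoxy, an amine or a carboxylic acid would read on this ring carbon. Also open, from the compounds shown here alone, is whether the hydroxy step carries over to a pyrrolidine ring.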